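The source may hold more compounds than are shown below. What is called first, only, known or untested is meant among the compounds shown, and "the series" means these compounds.

Compound 1 `ClCc1cccc(Cn2cnc3c(Cl)nc(Cl)nc32)c1` was tested in a functional assay on TK-10 cells (Homo sapiens) for cytotoxicity, read by sulforhodamine B assay, with a stated time of 48 h (on this read-out lower numbers stand for stronger inhibition of growth and higher numbers for weaker inhibition of growth), and gives 1730 nM. A second compound, compound 2 `ClCc1ccccc1Cn1cnc2ncnc(Cl)c21`, has also been measured in this assay, and compound 2 gives 3460 nM. Among the measured compounds shown here, compound 1 thus holds one of only two numbers so far, and the two numbers lie within the usual scatter of repeated measurements of each other, so neither compound can be placed ahead of the other and no trend can be drawn from them.

The compound not yet measured is compound 3 `Nc1nc(Cl)c2ncn(Cc3cccc(CCl)c3)c2n1`. It differs from compound 1 in one place: amino in place of chloro on an aromatic carbon. For the measured compounds named here, no pair of measured compounds shows this exchange, so nothing measured tells how large a shift it brings. Going by the values given here, with the rest of the structure kept in place and only one small group exchanged on the shared core, the expectation is for little or no shift beyond the scatter in this assay, and the expected step of a 1.4-fold higher number from compound 1 to compound 3 (0.16 log units; within the scatter) reflects that. Compound 3 is therefore estimated at 2500 nM, with a likely range from 900 nM to 7000 nM.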

Compound 3, concentration for 50% growth inhibition: 2390 nM
Compound 3: the middle estimate sits 1.0-fold (0.02 log units) above what was measured; the range from low to high includes it.
By their numbers in this assay, from the lowest: compounds 1, 3 and 2 (each within the scatter of the next).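

In this assay, the exchange of chloro for amino on an aromatic carbon, between two ring nitrogen atoms, gives a 1.4-fold higher number from compound 1 to compound 3 (0.14 log units; within the scatter). Among the compounds shown here, this is the first direct reading of a single change at this position, and it shows that the two compounds cannot be told apart in this test of cell growth. On this evidence the position accepts either group, even though chloro brings no hydrogen-bond donor or acceptor and amino brings one of each, and no measurement shown here offers an explanation for the match between the two numbers.

On these data alone, one exchange at one position says little about the range of groups this site can hold, so it remains open whether a hydroxyl, a methoxy group or a larger amine such as dimethylamino would also leave the number in the same region or would move it beyond the scatter. As far as these compounds go, it is also open whether amino would give the same result on a compound with a different side chain, because this single pair holds the rest of the structure fixed and shows the exchange in only that one setting.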